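Swapping Cyano for tert-Butyl in a Series at the Limit

A few compounds are considered here, and "the series" means these few. Any claim that something is new, unique, unknown or untested is made for them only; others in the source may bear on it.

Compound 1 `Cc1ccccc1-n1cc(CNC(=O)c2cccc3c2cnn3C(C)C)nn1` gives in a functional assay on MCF7 cells (Homo sapiens) for inhibition, read by MTT assay, with a stated time of 72 h (a lower number here means a stronger inhibitor, a higher number a weaker inhibitor), only a limit of > 40000 nM. Compound 2 `CC(C)n1ncc2c(C(=O)NCc3cn(Cc4ccc(C(F)(F)F)cc4)nn3)cccc21` gives in this assay a limit of > 40000 nM. Compound 3 `CC(C)n1ncc2c(C(=O)NCc3cn(Cc4ccc(C#N)cc4)nn3)cccc21` gives in this assay a limit of > 40000 nM.

Compound 3 therefore stands at the limit of the assay and not at a number, and the same is true of both other measured compounds, so none of the three can be ranked against another. Compound 4 `CC(C)n1ncc2c(C(=O)NCc3cn(Cc4ccc(C(C)(C)C)cc4)nn3)cccc21` differs from compound 3 by tert-butyl in place of cyano on an aromatic carbon.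

Two measured steps lead into compound 3. For the measured compounds named here, the first is a step that the two limits leave unreadable from compound 1 to compound 3 and the second is a step that the two limits leave unreadable from compound 2 to compound 3. Neither step has a readable size, because all three values sit at the limit of > 40000 nM in this assay, at which 3 of the 3 values shown sit. Going by the values given here, these steps show only that changing the group on the benzyl ring, or replacing the whole group on the aromatic nitrogen, left the read-out at the limit; they give no sign of a direction.

With that background, compound 4 is expected to remain at the limit as well, and the expected step of a number no higher from compound 3 to compound 4 (the limit leaves the size open) is none beyond the scatter. The estimate for compound 4 in this assay is 40000 nM, with a range from 15000 nM to 120000 nM.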

Compound 4, half-maximal inhibitory concentration: > 40000 nM
Compound 4 gave a limit, no number (the forecaster's own chance of this, stated with the estimate: 80%); the middle value sits exactly at the limit.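

The steps from compound 3 and from compound 2 to compound 4 cannot be read, and none of the four compounds can be ranked against another: the limit of > 40000 nM in this assay, at which 4 of the 4 values shown sit.

The compounds shown leave open what number each one would give in this assay, and whether any change to the group on the triazole-free end of the shared core would produce a measurable value.

Correction to the final sentence: The compounds shown leave open what number each one would give in this assay, and whether any other group in this place would produce a measurable value.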